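Replacing the pentafluorophenyl group of compound 3

The source may report more compounds than this note shows. Statements on the series, on what has been measured and on what is new or still open speak of the compounds shown alone.

Three compounds share one core and differ only in the fluorinated phenyl group on an oxygen on a saturated carbon. In a functional assay on Jurkat cells (Homo sapiens) (on this read-out higher numbers stand for weaker inhibition and lower numbers for stronger inhibition), compound 1 `CC(C)[C@H](NC(=O)COc1cccc2ccccc12)C(=O)N[C@@H](CC(=O)O)C(=O)COc1ccc(F)cc1F` gives 33200 nM. Compound 2 `CC(C)[C@H](NC(=O)COc1cccc2ccccc12)C(=O)N[C@@H](CC(=O)O)C(=O)COc1cc(F)cc(F)c1` gives > 100000 nM, which is a limit of the assay and not a number. Compound 3 `CC(C)[C@H](NC(=O)COc1cccc2ccccc12)C(=O)N[C@@H](CC(=O)O)C(=O)COc1c(F)c(F)c(F)c(F)c1F` gives 3050 nM, the lowest number of the three and the strongest inhibition.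

Compound 4 `CC(C)[C@H](NC(=O)COc1cccc2ccccc12)C(=O)N[C@@H](CC(=O)O)C(=O)COc1ccc([N+](=O)[O-])cc1F` has 2-fluoro-4-nitrophenyl in place of 2,3,4,5,6-pentafluorophenyl on an oxygen on a saturated carbon. Going by the values given here, no measured compound carries a nitro group, so the steps that bear on this change are only indirect guides. Moving fluorines alone gave an at least 3.0-fold higher number from compound 1 to compound 2 (0.47 log units; beyond the scatter), and adding them gave an at least 32-fold lower number from compound 2 to compound 3 (1.51 log units; beyond the scatter). The closest guide is an 11-fold lower number from compound 1 to compound 3 (1.04 log units; beyond the scatter), since the name 2,4-difluorophenyl in compound 1 has the same numbering as the incoming group. Read in reverse, that step suggests losing part of the gain in this assay. The expected change is moderate, a 3.3-fold higher number from compound 3 to compound 4 (0.52 log units; beyond the scatter), though it is uncertain. For compound 4 the estimated value is 10000 nM, with an expected range of 2000 nM to 50000 nM.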

Compound 4, half-maximal inhibitory concentration: 30300 nM
For compound 4 the middle estimate is 3.0-fold (0.48 log units) below the measured one; the measured number falls inside the stated range.
By their numbers in this assay, from the lowest: compound 3; then compounds 4 and 1 (each within the scatter of the next). At a limit, above all of these: compound 2.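

In this assay, nitro in place of fluoro on an aromatic carbon leaves the two compounds level: a 1.1-fold lower number from compound 1 to compound 4 (0.04 log units; within the scatter). At this position, then, the nitro group does not recover what the pentafluorophenyl group gives, as the step to 2-fluoro-4-nitrophenyl shows: a 9.9-fold higher number from compound 3 to compound 4 (1.00 log units; beyond the scatter). The arrangement of groups on the ring still matters, with an at least 3.3-fold lower number from compound 2 to compound 4 (0.51 log units; beyond the scatter), but the size of that step is open-ended as compound 2 stands at a limit and not at a number: the limit of > 100000 nM in this assay, at which 1 of the 4 values shown sits.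

From the compounds shown here alone, whether a nitrile or an amine on that same aromatic carbon would also sit level with compound 1 remains open. So does how a nitrophenyl group carrying no fluorine would behave on the shared core.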